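The source may report more compounds than this note shows. Statements on the series, on what has been measured and on what is new or still open speak of the compounds shown alone.

For the measured compounds named here, compound 1 `C=C(Br)C(=O)Nc1cccc(-c2cn3nc(-c4ccccc4)sc3n2)c1` gives the lowest of the three numbers so far in a functional assay on HeLa cells (Homo sapiens) for inhibition, read by cell counting, with a stated time of 4 days (a higher number here means a weaker inhibitor, a lower number a stronger inhibitor), at 1400 nM. Compound 2 `COc1ccc(-c2csc3nc(-c4cccc(N)c4)cn23)cc1` gives 19000 nM, and compound 3 `Nc1cccc(-c2cn3nc(-c4ccccc4)sc3n2)c1` gives 26000 nM; these two values lie within the scatter of each other. The step of a 19-fold higher number from compound 1 to compound 3 (1.27 log units; beyond the scatter) concerns a different part of the molecule, so it does not speak to the present change. Compound 4 `C=C(Br)C(=O)Nc1cccc(-c2cn3nc(-c4ccc(OC)cc4)sc3n2)c1` differs from compound 1 by methoxy in place of hydrogen on an aromatic carbon. Compounds 2 and 3, whose values differ only within the scatter, are the nearest comparison. The step of a 1.1-fold lower number from compound 1 to compound 4 (0.03 log units; within the scatter) is therefore expected to stay within the scatter. Compound 4 is estimated at 1300 nM, with a range from 500 nM to 3500 nM.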

Compound 4, half-maximal inhibitory concentration: 2300 nM
Beside the measured number, compound 4's estimate is 1.8-fold (0.25 log units) below it; low and high end bracket the measured number.
By their numbers in this assay, from the lowest: compounds 1 and 4 (each within the scatter of the next); then compounds 2 and 3 (each within the scatter of the next).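

Turning phenyl into 4-methoxyphenyl gives a 1.6-fold higher number from compound 1 to compound 4 (0.22 log units; within the scatter) in this assay. This is the first pair shown that differs only at this aromatic carbon, and it shows that methoxy can replace hydrogen here with the (1-bromoethenyl)carbonyl group kept, without moving the number beyond the usual scatter. No measurement shown here accounts for this result. Still open, from the compounds shown here alone, is whether a larger or differently charged replacement, such as an amine, a carboxylic acid or a longer chain like butoxy, would also stay within the scatter at this place.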